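Trimming the tert-Butyl Sulfonamide of Compound 1

The compounds below may be only part of what the source reports. "The series", "measured", "known", "first", "only" and "open" are said of these compounds alone.

Of the compounds shown here, three sharing a piperidinyl-piperidine sulfonamide core have been tested in a functional assay on DLD-1 cells (Homo sapiens) for antiproliferative activity, read by CellTiter-Glo, with a stated time of 72 h; on this read-out higher numbers stand for weaker inhibition and lower numbers for stronger inhibition. Compound 1 `CC1CCN(C2CCN(S(=O)(=O)c3ccc(C(C)(C)C)cc3)CC2)CC1` carries a tert-butyl-substituted aryl sulfonyl group. In this assay compound 1 returns only the limit of > 5000 nM, not a number. Compound 2 `Cc1c(C)c(S(=O)(=O)N2CCC(N3CCC(C)CC3)CC2)c(C)c2c1OC(C)(C)C2`, with a fused, heavily methylated aromatic sulfonyl group, gives 1.2 nM in this assay. Compound 3 `CC1CCN(C2CCN(S(=O)(=O)c3cccc(-c4ccc(Cl)cc4)c3)CC2)CC1`, bearing a chlorophenyl-substituted aryl sulfonyl group, gives 15 nM in this assay. Compound 1 thus stands apart from the other two, being the one of the three that sits at the limit of > 5000 nM in this assay, at which 1 of the 3 values shown sits.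

Compound 4 `CC1CCN(C2CCN(S(=O)(=O)c3ccc(C(C)C)cc3)CC2)CC1` has not yet been measured. It differs from compound 1 in a single place: hydrogen in place of methyl on a saturated chain carbon bound to an aromatic carbon and two saturated chain carbons. Going by the values given here, since no step between measured compounds isolates this change, the expectation rests only on where compound 1 stands. The step of a number no higher from compound 1 to compound 4 (the limit leaves the size open) is expected to be small, with no clear direction beyond the scatter. Compound 4 is accordingly expected to give about 5000 nM in this assay, within a range from 1000 nM to 20000 nM, and it may well return only a limit.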

Compound 4, half-maximal inhibitory concentration: 685 nM
Compound 4: middle estimate off by 7.3-fold (0.86 log units), on the high side, outside the stated range (below it).
By their numbers in this assay, from the lowest: compound 2; then compound 3; then compound 4. At a limit, above all of these: compound 1.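

In this assay, the change from tert-butyl to isopropyl, with hydrogen in place of methyl on a saturated chain carbon bound to an aromatic carbon and two saturated chain carbons, gives an at least 7.2-fold lower number from compound 1 to compound 4 (0.86 log units; beyond the scatter). Going by these compounds alone, the earlier compounds offered no step that differed in one place, so this is the first direct sign that this position matters: removing a single methyl, with the rest of compound 1 unchanged, is enough to turn a limit into a measured number. The true size of the step stays open on one side because the starting point of compound 1 is a limit of the assay and not a number: the limit of > 5000 nM in this assay, at which 1 of the 4 values shown sits.

The compounds shown leave open whether further trimming of the same group to an ethyl or a plain methyl, or removing it altogether, would carry the number lower still or turn it back up. They also leave open whether a cyclopropyl or a methoxy group in this place would behave like isopropyl, and what lies behind the step, which these values alone cannot tell.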